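Compound 2 to compound 3: exchanging the side group

The source may report more compounds than this note shows. Statements on the series, on what has been measured and on what is new or still open speak of the compounds shown alone.

Going by the values given here, in a functional assay on PANC-1 cells (Homo sapiens) for antiproliferative activity, read by WST assay, with a stated time of 96 h (on this read-out higher numbers stand for weaker inhibition and lower numbers for stronger inhibition), compound 2 `CCC[C@H]1C[C@@H](OC)C/C(C)=C\[C@@H]2C[C@@H](OC(=O)/C=C\CCc3coc(C=C(C)C)n3)C[C@H](CC(=O)O1)O2` gives 2800 nM, the higher of the two numbers so far, while compound 1 `CCC[C@H]1C[C@@H](OC)C/C(C)=C\[C@@H]2C[C@@H](OC(=O)/C=C\CCc3coc(/C=C\CNC(=O)OC)n3)C[C@H](CC(=O)O1)O2` gives 2.4 nM. Compound 3 `CCC[C@H]1C[C@@H](OC)C/C(C)=C\[C@@H]2C[C@@H](OC(=O)/C=C\CCc3coc(CCCNC(=O)OC)n3)C[C@H](CC(=O)O1)O2` is still unmeasured. Its change from compound 2 is 3-((methoxycarbonyl)amino)propyl in place of 2-methylprop-1-en-1-yl on an aromatic carbon. Among the compounds with values here, one measured step bears on this, and it is large: a 1200-fold higher number from compound 1 to compound 2 (3.07 log units; beyond the scatter), with 2-methylprop-1-en-1-yl replacing 3-((methoxycarbonyl)amino)prop-1-en-1-yl. Within the data shown here, the entering propyl group is not the prop-1-en-1-yl group of compound 1, and no measured step covers that difference, so only part of that gap is expected to close. The expected change in this assay is large and toward a lower number, a 93-fold lower number from compound 2 to compound 3 (1.97 log units; beyond the scatter). For compound 3 the estimated value is 30 nM, with an expected range of 4 nM to 300 nM.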

Compound 3, half-maximal inhibitory concentration: 200 nM
Estimate against measurement, compound 3: 6.7-fold (0.82 log units) below; measured number inside the range.
By their numbers in this assay, from the lowest: compound 1; then compound 3; then compound 2.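

In this assay the 3-((methoxycarbonyl)amino)propyl group on this aromatic carbon brings a 14-fold lower number from compound 2 to compound 3 (1.15 log units; beyond the scatter) and so recovers part of the loss seen with 2-methylprop-1-en-1-yl, even without a carbon-carbon double bond in the chain. The chain's unsaturation also counts on its own: an 83-fold higher number from compound 1 to compound 3 (1.92 log units; beyond the scatter) is the step when only that feature differs, so the terminal carbamate does not account for the full activity of compound 1. No available data give a reason for either step.

The compounds shown leave open whether the methoxycarbonyl cap matters, as a free primary amine or a carboxylic acid at the chain end would show. They also leave open how a butyl chain with the same cap, or a carbon-carbon triple bond in the chain, would compare.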